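This account rests on a few compounds, and the source may have more. Where it says the series, first, only, none or still open, it means among the compounds named here.

Measured compounds:
compound 1 `N#Cc1ccc(-n2cc(-c3n[nH]c4cc(Cl)c(N[C@@H]5CCNC5)cc34)cn2)cc1` gives 700 nM
compound 2 `Fc1ccc(-n2cc(-c3n[nH]c4cc(Cl)c(N[C@@H]5CCNC5)cc34)cn2)cc1` gives 2300 nM
compound 3 `Cn1cc(-c2n[nH]c3ccc(-c4ccccc4)cc23)cn1` gives 620 nM

In an assay on isolated protein for inhibition of tyrosine-protein kinase receptor UFO (Homo sapiens), with a stated time of 1.5 h (a higher number here means a weaker inhibitor, a lower number a stronger inhibitor), compound 2 has the highest number of the three. Among the compounds with values here, its nearest neighbour is compound 1, and the single change between them, fluoro in place of cyano on an aromatic carbon, gives a 3.3-fold higher number from compound 1 to compound 2 (0.52 log units; beyond the scatter). Compound 3, built on a different core, shows a number of the same order as compound 1.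

Compound 4 `COc1ccc(-n2cc(-c3n[nH]c4cc(Cl)c(N[C@@H]5CCNC5)cc34)cn2)cc1` differs from compound 2 by methoxy in place of fluoro on an aromatic carbon. Within the data shown here, no measured pair shows methoxy replacing fluoro, so the only step that bears on this position is the one from compound 1 to compound 2, which tells that a change at this aromatic carbon can move the number by a modest amount. The direction for methoxy is not fixed by the data. It is expected that compound 4 lands close to compound 2 or somewhat below it, a step of a 1.5-fold lower number from compound 2 to compound 4 (0.19 log units; within the scatter). Compound 4 is therefore estimated at 1500 nM, within a range from 500 nM to 4500 nM.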

Compound 4, half-maximal inhibitory concentration: 300 nM
Compound 4: the middle estimate sits 5.0-fold (0.70 log units) above what was measured, and the stated range ends above it.
By their numbers in this assay, from the lowest: compound 4; then compounds 3 and 1 (each within the scatter of the next); then compound 2.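

Within the data shown here, at this aromatic carbon, methoxy gives a 7.7-fold lower number from compound 2 to compound 4 (0.88 log units; beyond the scatter) in this assay and so turns the 4-fluorophenyl compound into the one with the lowest number of the series. Methoxy also outdoes the nitrile, with a 2.3-fold lower number from compound 1 to compound 4 (0.37 log units; beyond the scatter) here, which shows that the nitrile of the earlier pair did not mark the best result at this place and that the three groups run methoxy, nitrile, fluoro from the lowest number to the highest. Nothing at hand accounts for this order.

The compounds shown leave open how other groups at this carbon would compare, such as an amine, a carboxylic acid or a longer chain like ethoxy. They also leave open whether the same order would hold if the shared core were changed elsewhere.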